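This account rests on a few compounds, and the source may have more. Where it says the series, first, only, none or still open, it means among the compounds named here.

Measured compounds in a functional assay on CCRF-CEM cells (Homo sapiens) for cytotoxicity; on this read-out lower numbers stand for stronger inhibition and higher numbers for weaker inhibition:
compound 1 `O=C(/C=C/C(=O)N1C/C(=C\c2ccccc2)C(=O)/C(=C/c2ccccc2)C1)Nc1ccccc1` — 1100 nM
compound 2 `Cc1cccc(C)c1NC(=O)/C=C/C(=O)N1C/C(=C\c2ccc([N+](=O)[O-])cc2)C(=O)/C(=C/c2ccc([N+](=O)[O-])cc2)C1` — 230 nM
compound 3 `O=C(/C=C/C(=O)N1C/C(=C\c2ccc([N+](=O)[O-])cc2)C(=O)/C(=C/c2ccc([N+](=O)[O-])cc2)C1)Nc1ccc(Cl)cc1` — 810 nM

Compound 1 gives the highest of the three numbers. Its gap to compound 3 is within the scatter, so those two cannot be ordered; its gap to compound 2 is beyond the scatter. For the measured compounds named here, the only single-site step in the set is a 3.5-fold higher number from compound 2 to compound 3 (0.55 log units; beyond the scatter), a change of the aryl on the amide-type nitrogen; it shows that this position moves the read-out, though only modestly. Going by the values given here, compound 1 and compound 3 differ in two places at once, so their two values give no clean step of their own.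

Compound 4 `O=C(/C=C/C(=O)N1C/C(=C\c2ccccc2)C(=O)/C(=C/c2ccccc2)C1)Nc1ccc([N+](=O)[O-])cc1` is compound 1 with nitro in place of hydrogen on an aromatic carbon, that is, phenyl to 4-nitrophenyl on the amide-type nitrogen. Among the compounds with values here, no measured pair carries this exact change; the one amide-aryl step available, a 3.5-fold higher number from compound 2 to compound 3 (0.55 log units; beyond the scatter), was modest and involved other groups, so it sets a rough scale but fixes no direction for nitro. The expectation is therefore a small step, a 1.2-fold lower number from compound 1 to compound 4 (0.09 log units; within the scatter), most likely not beyond the scatter. Compound 4 is estimated at 900 nM, with a range of 350 nM to 2500 nM.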

Compound 4, half-maximal inhibitory concentration: 40000 nM
Compound 4: the middle estimate sits 44-fold (1.65 log units) below what was measured, and the stated range ends below it.
By their numbers in this assay, from the lowest: compound 2; then compounds 3 and 1 (each within the scatter of the next); then compound 4.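

In this assay, for the compounds shown here, the aryl on the amide-type nitrogen proves far more sensitive than the earlier compounds indicated, with a large step of a 36-fold higher number from compound 1 to compound 4 (1.56 log units; beyond the scatter) for nitro in place of hydrogen on an aromatic carbon. Going by these compounds alone, the only earlier step at this position was modest at a 3.5-fold higher number from compound 2 to compound 3 (0.55 log units; beyond the scatter) and involved other groups, so it gave no direction for nitro. The new step supplies that direction on the core of compound 1, towards weaker inhibition, and shows that one substituent para to a large group, on a six-membered aromatic ring of carbon only, can move the read-out much further than the earlier step did. Nothing available here accounts for the size of this step.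

The compounds shown leave open whether this large step belongs to nitro itself or would appear with other groups at the same place, such as an amine or a carboxylic acid. They also leave open whether nitro at this place would give a step of similar size on a core bearing the 4-nitrophenyl groups of compound 3.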